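Swapping methoxy for a trifluoromethyl ketone on the aryl

The compounds below may be only part of what the source reports. "The series", "measured", "known", "first", "only" and "open" are said of these compounds alone.

Measured so far:
compound 1, `COC(=O)c1ccccc1-c1cnc(C(=O)CCCCCCc2ccccc2)o1`: 60 nM
compound 2, `COc1ccccc1-c1cnc(C(=O)CCCCCCc2ccccc2)o1`: 400 nM

In an assay (Rattus norvegicus) for inhibition of Fatty-acid amide hydrolase 1 (Homo sapiens) (a lower number here means a stronger inhibitor, a higher number a weaker inhibitor), compound 2 gives 400 nM, the higher of the two numbers; its nearest neighbour is compound 1 with 60 nM. Within the data shown here, the only measured step, a 6.7-fold higher number from compound 1 to compound 2 (0.82 log units; beyond the scatter), shows that trading the methoxycarbonyl for methoxy made the inhibitor weaker. Compound 3, `O=C(CCCCCCc1ccccc1)c1ncc(-c2ccccc2C(=O)C(F)(F)F)o1`, differs from compound 2 by (trifluoromethyl)carbonyl in place of methoxy on an aromatic carbon, a (trifluoromethyl)carbonyl in place of methoxy on an aromatic carbon, ortho to a large group. This change restores a carbonyl at the position where compound 1 carried one, so the step from compound 1 to compound 2 is the one that bears on it, and a step of roughly that size in the opposite direction, back toward a lower number, is expected in this assay. Compound 3 is therefore estimated at 80 nM, within 20 nM to 300 nM. The expected step is a 5.0-fold lower number from compound 2 to compound 3 (0.70 log units; beyond the scatter).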

Compound 3, inhibition constant: 5000 nM
Beside the measured number, compound 3's estimate is 63-fold (1.80 log units) below it; the whole stated range lies below it.
By their numbers in this assay, from the lowest: compound 1; then compound 2; then compound 3.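

In this assay, (trifluoromethyl)carbonyl on this aromatic carbon gives a 13-fold higher number from compound 2 to compound 3 (1.10 log units; beyond the scatter), so restoring a carbonyl here does not by itself restore strength. What is attached to that carbonyl matters greatly: trifluoromethyl in place of methoxy on the carbonyl carbon gives an 83-fold higher number from compound 1 to compound 3 (1.92 log units; beyond the scatter), even though both groups keep the carbonyl on the same aromatic carbon. Nothing available explains why this swap weakens inhibition so sharply. The compounds shown leave open whether a carboxylic acid, an amide or a nitrile on this aromatic carbon would match or beat methoxycarbonyl. They also leave open whether the same order of the three groups would hold with a shorter chain on the other side of the core.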